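The compounds below may be only part of what the source reports. "The series", "measured", "known", "first", "only" and "open" are said of these compounds alone.

Notes on the series. The shared core of compound 1 `Clc1ccccc1-c1cc(-c2cnn(C3CCNCC3)c2)on1` carries a phenyl ring bearing a single chlorine; in an assay on a protein complex for positive allosteric modulation of Neuronal acetylcholine receptor; alpha4/beta2 (Homo sapiens) (a lower number here means a smaller maximal response, a higher number a larger maximal response), compound 1 gives 38%. Compound 2 `Fc1cccc(Cl)c1-c1cc(-c2cnn(C3CCNCC3)c2)on1` adds a fluorine to that ring and gives 60%, the second highest of the three numbers measured; compound 3 `Cc1c(-c2cc(-c3c(F)cccc3Cl)no2)cnn1C1CCNCC1` gives 66%. The two measured steps are a number 22 percentage points higher from compound 1 to compound 2 (beyond the scatter) and a number 6 percentage points higher from compound 2 to compound 3 (within the scatter). Compound 4 `Clc1cnccc1-c1cc(-c2cnn(C3CCNCC3)c2)on1` differs from compound 2 by 3-chloropyridin-4-yl in place of 2-chloro-6-fluorophenyl on an aromatic carbon. Going by the values given here, no measured step bears on the ring nitrogen, and the only step touching the fluorine is the one from compound 1 to compound 2. A step of a number 15 percentage points lower from compound 2 to compound 4 (beyond the scatter) in this assay is therefore expected, downward. For compound 4 in this assay the estimate is 45%, ranging from 25% to 70%.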

Compound 4, largest response reached (reported as efficacy), in percent of the reference or control that the assay uses: 50%
Compound 4: the middle estimate sits 5 percentage points below what was measured, and the stated range covers the measured number.
By their numbers in this assay, from the lowest: compound 1; then compounds 4, 2 and 3 (each within the scatter of the next, the first and the last beyond it).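

Replacing 2-chloro-6-fluorophenyl with 3-chloropyridin-4-yl gives a number 10 percentage points lower from compound 2 to compound 4 (within the scatter) in this assay and shows that this position accepts an aromatic ring with a ring nitrogen and no fluorine. Against 2-chlorophenyl, the same group gives a number 12 percentage points higher from compound 1 to compound 4 (beyond the scatter) and so raises the maximal response without fluorine, which the earlier compounds did not show. No available evidence accounts for either step.

Still open, from the compounds shown here alone, is whether the chlorine on the 3-chloropyridin-4-yl group can give way to a methoxy group or an amine. Also open, going by these compounds, is whether the methyl group of compound 3 would have any effect on compound 4.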